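Opening a Ring: Where Compound 4 Might Land

The source may hold more compounds than are shown below. What is called first, only, known or untested is meant among the compounds shown, and "the series" means these compounds.

Compound 1 `O=C(NC1(C(=O)NO)CCC1)c1ccc(C#Cc2ccccc2)cc1` is one of three measured compounds built on the shared core. In a physicochemical assay for lipophilicity (on this read-out lower numbers stand for lower lipophilicity and higher numbers for higher lipophilicity), compound 1 gives > 3, which is a limit of the assay rather than a number. Compound 2 `O=C(NC1(C(=O)NO)CCCCC1)c1ccc(C#Cc2ccccc2)cc1` carries a larger ring in the same position; in this assay compound 2 gives > 3, again a limit and not a measured number. Going by the values given here, compound 3 `O=C(NC1(C(=O)NO)CCS(=O)(=O)CC1)c1ccc(C#Cc2ccccc2)cc1` is the only one with a real number: in this assay compound 3 gives 3. Among the compounds with values here, compound 1 therefore stands at the limit of > 3 in this assay, at which 2 of the 3 values shown sit, and with two of three values sitting at that limit, no step between any pair of measured compounds can be drawn from these data.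

Compound 4 `CSC[C@H](NC(=O)c1ccc(C#Cc2ccccc2)cc1)C(=O)NO` has not yet been measured. Set against compound 1, the change is a group of 8 heavy atoms (4 carbon, 1 nitrogen, 2 oxygen, 1 sulfur; no ring) in place of a group of 8 heavy atoms (5 carbon, 1 nitrogen, 2 oxygen; one four-membered non-aromatic ring of carbon only), on an amide-type nitrogen. Within the data shown here, no measured step offers a template for the size of this change, so the expectation rests on the structures alone: a modest move downward in this assay, expressed as the expected step of a number at least 0.30 log units lower from compound 1 to compound 4 (that floor lies within the scatter), with a fair chance that the assay again reports only its limit. On that basis compound 4 is estimated at 2.7, within a range from 2.2 to 3.2.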

Compound 4, distribution coefficient: 3
Beside the measured number, compound 4's estimate is 0.30 log units below it; low and high end bracket the measured number.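

Swapping the 1-(hydroxycarbamoyl)cyclobutyl group for a group with no ring, on the same amide-type nitrogen, gives in this assay a number no higher from compound 1 to compound 4 (the limit leaves the size open). Compound 1 gives > 3, which is a limit and not a number, so the size of this step cannot be read because that value sits at the limit of the assay: the limit of > 3 in this assay, at which 2 of the 4 values shown sit. What is new is that a group with no ring at this place gives a real number, and that number prints the same as the only other one in the set, since compound 3 gives 3 and compound 4 gives 3.

This one change removes the ring and brings in a sulfur atom together, so the compounds shown do not separate what each of the two contributes, and the true distance between compound 1 and compound 4 stays unknown. They also leave open what an amine or a carboxylic acid at this place, or a longer chain without sulfur, would give in this assay.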